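The source may report more compounds than this note shows. Statements on the series, on what has been measured and on what is new or still open speak of the compounds shown alone.

Measured compounds:
compound 1, `O=[N+]([O-])c1cc(C(F)(F)F)cc([N+](=O)[O-])c1Oc1ccccc1/C=N\OCc1ccccc1`: 1470 nM
compound 2, `O=[N+]([O-])c1cc(C(F)(F)F)cc([N+](=O)[O-])c1Oc1ccccc1/C=N\OCc1ccccc1F`: 860 nM
compound 3, `O=[N+]([O-])c1cc(C(F)(F)F)cc([N+](=O)[O-])c1Oc1ccc(Cl)cc1/C=N\OCc1ccccc1F`: 2570 nM

In a functional assay on A549 cells (Homo sapiens) for antiproliferative activity, read by MTT assay, with a stated time of 48 h (a higher number here means a weaker inhibitor, a lower number a stronger inhibitor), compound 3 shows the highest of the three numbers; its gap to compound 1 lies within the scatter, while its gap to compound 2 lies beyond it. Compound 4, `O=[N+]([O-])c1cc(C(F)(F)F)cc([N+](=O)[O-])c1Oc1ccc(Cl)cc1/C=N\OCc1ccc(Cl)cc1Cl`, differs from compound 3 by 2,4-dichlorophenyl in place of 2-fluorophenyl on a saturated chain carbon bound to an oxygen. Going by the values given here, no measured step alters this benzyl ring in the same way. The step of a 1.7-fold lower number from compound 1 to compound 2 (0.23 log units; within the scatter) stayed within the scatter, and the step of a 3.0-fold higher number from compound 2 to compound 3 (0.48 log units; beyond the scatter) was modest, so halogen changes on these rings moved the number only slightly. Compound 4 is therefore expected to sit near compound 3, with a step of a 1.0-fold higher number from compound 3 to compound 4 (0.01 log units; within the scatter) not clearly beyond the scatter, estimated at 2600 nM within 900 nM to 7500 nM.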

Compound 4, half-maximal inhibitory concentration: 3440 nM
Beside the measured number, compound 4's estimate is 1.3-fold (0.12 log units) below it; measured number inside the range.
By their numbers in this assay, from the lowest: compounds 2, 1, 3 and 4 (each within the scatter of the next, the first and the last beyond it).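

In this assay, 2,4-dichlorophenyl in place of 2-fluorophenyl on a saturated chain carbon bound to an oxygen gives a 1.3-fold higher number from compound 3 to compound 4 (0.13 log units; within the scatter). The earlier steps shown here each replaced a single hydrogen, whereas this one exchanges a fluorine for two chlorines, and the number still stays within the scatter. Nothing available explains this result. On these data alone, it remains open whether a methoxy group or an amine on this phenyl ring, or a pyridine ring in its place, would leave the number equally close.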